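Sulfonylpiperazine series: aryl in place of benzyl on the ring nitrogen

This account rests on a few compounds, and the source may have more. Where it says the series, first, only, none or still open, it means among the compounds named here.

Of the compounds shown here, two have been measured in an assay on CHO cells for displacement of a labelled ligand from adenosine receptor A1 (Homo sapiens), read by scintillation counting, with a stated time of 90 min, in the presence of a further agent that is not named here; on this read-out lower numbers stand for stronger inhibition and higher numbers for weaker inhibition. Compound 1 `CCCn1c(=O)[nH]c2nc(-c3ccc(S(=O)(=O)N4CCN(c5ccc(Br)cc5)CC4)cc3)[nH]c2c1=O` carries 4-bromophenyl on the piperazine nitrogen; in this assay compound 1 reaches only the limit > 1000 nM, not a number. Within the data shown here, compound 2 `CCCn1c(=O)[nH]c2nc(-c3ccc(S(=O)(=O)N4CCN(Cc5cccc(C)c5)CC4)cc3)[nH]c2c1=O` carries 3-methylbenzyl on that nitrogen; in this assay compound 2 gives 795 nM, the only numerical value in the set. The step of an at least 1.2-fold lower number from compound 1 to compound 2 (0.09 log units; that floor lies within the scatter) rests on the limit of > 1000 nM in this assay, at which 1 of the 2 values shown sits, and lies within the scatter.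

Compound 3 `CCCn1c(=O)[nH]c2nc(-c3ccc(S(=O)(=O)N4CCN(c5ccccc5C)CC4)cc3)[nH]c2c1=O` differs from compound 2 in one place: 2-methylphenyl in place of 3-methylbenzyl on an amine nitrogen in a ring. Among the measured compounds shown here, the one measured step bearing on this change is an at least 1.2-fold lower number from compound 1 to compound 2 (0.09 log units; that floor lies within the scatter), which runs in the reverse sense, from a phenyl on the nitrogen to a benzyl, and brought compound 1 from a limit to a number. Compound 3 returns to a phenyl on that nitrogen, so the expectation is a move back toward weaker binding, possibly to the limit again. The expected step is a 1.9-fold higher number from compound 2 to compound 3 (0.28 log units; within the scatter). Compound 3 is estimated at 1500 nM, within 500 nM to 5000 nM.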

Compound 3, inhibition constant: 419 nM
Beside the measured number, compound 3's estimate is 3.6-fold (0.55 log units) above it; the whole stated range lies above it.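

In this assay, 2-methylphenyl in place of 3-methylbenzyl on the amine nitrogen in the ring gives a 1.9-fold lower number from compound 2 to compound 3 (0.28 log units; within the scatter), so the two compounds cannot be told apart, and an aryl group set directly on that nitrogen does not by itself lead to the limit seen for compound 1. The first step in the series beyond the scatter comes instead from exchanging one aryl group for another, an at least 2.3-fold lower number from compound 1 to compound 3 (0.37 log units; beyond the scatter), and it is only a floor, since it rests on a limit: the limit of > 1000 nM in this assay, at which 1 of the 3 values shown sits.
On these data alone, compound 1 is held at > 1000 nM, which is a limit and not a number, so the true size of this step stays unknown.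

Because 2-methylphenyl and 4-bromophenyl differ both in the group carried and in where it stands on the aromatic ring, the compounds shown do not tell whether the methyl group, the bromine or the placement decides the step, and an unsubstituted phenyl or a 2-bromophenyl would separate these. Also open, as far as these compounds go, is whether a group of another kind on that nitrogen, such as a carboxylic acid on the aromatic ring or a longer chain to it, would move the number beyond the scatter from compound 2 or compound 3.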